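A few compounds are considered here, and "the series" means these few. Any claim that something is new, unique, unknown or untested is made for them only; others in the source may bear on it.

For the measured compounds named here, compound 2, `COc1ccc2[nH]c(C(=O)N3CC(=O)N(Cc4ccccc4)[C@@H](CN4CC5CCCC5C4)C3)cc2c1`, gives 10600 nM in an ADME assay on Vero cells (Chlorocebus sabaeus) for cytotoxicity, with a stated time of 7 days (a lower number here means that less compound is tolerated, a higher number that more compound is tolerated), the lowest of the two numbers measured so far; compound 1, `COc1ccc2[nH]c(C(=O)N3CC(=O)N(Cc4ccccc4)[C@@H](CN4CC5(CCC5)C4)C3)cc2c1`, gives 52700 nM in this assay. Going by the values given here, the only step measured so far is a 5.0-fold lower number from compound 1 to compound 2 (0.70 log units; beyond the scatter), where a larger saturated bicyclic amine on the side chain went with a lower tolerated concentration. Compound 3, `COc1ccc2[nH]c(C(=O)N3CC(=O)N(Cc4ccccc4)[C@@H](CN4CCc5ccccc5C4)C3)cc2c1`, carries a group of 10 heavy atoms (9 carbon, 1 nitrogen; one six-membered non-aromatic ring with 1 hetero atom, one six-membered aromatic ring of carbon only) in place of a group of 8 heavy atoms (7 carbon, 1 nitrogen; one five-membered non-aromatic ring of carbon only, one five-membered non-aromatic ring with 1 hetero atom), on a saturated chain carbon bound to a saturated ring carbon. Among the compounds with values here, no measured pair shows an aromatic ring entering at this position, so the single step from compound 1 to compound 2 is the only guide, and it points toward larger groups here being tolerated somewhat less. The step from compound 2 to compound 3 is therefore expected to be a 1.5-fold lower number from compound 2 to compound 3 (0.18 log units; within the scatter), a small decrease that may well sit inside the scatter. Compound 3 is estimated to give 7000 nM in this assay, within a range from 2500 nM to 20000 nM.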

Compound 3, half-maximal cytotoxic concentration: 51800 nM
Compound 3: the middle estimate sits 7.4-fold (0.87 log units) below what was measured; measured number above the stated range.
By their numbers in this assay, from the lowest: compound 2; then compounds 3 and 1 (each within the scatter of the next).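

In this assay, the 1,2,3,4-tetrahydroisoquinolin-2-yl group gives a 4.9-fold higher number from compound 2 to compound 3 (0.69 log units; beyond the scatter), so the earlier link between a larger group and a lower number does not hold across all three compounds: compound 3 carries the largest group by heavy atoms, yet compound 2 keeps the lowest number. Compared with the smallest group, the result is level, with a 1.0-fold lower number from compound 1 to compound 3 (0.01 log units; within the scatter), leaving compound 2 as the only one set apart from the other two. No measured evidence accounts for this difference.

From the compounds shown here alone, in this step, the size of the group and the presence of an aromatic ring change together, so their separate contributions remain open. A piperidin-1-yl or morpholin-4-yl group at this position would show how other rings without an aromatic part compare.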